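This account rests on a few compounds, and the source may have more. Where it says the series, first, only, none or still open, it means among the compounds named here.

In a functional assay on Jurkat cells (Homo sapiens) for inhibition, read by MTT assay, with a stated time of 72 h (on this read-out higher numbers stand for weaker inhibition of growth and lower numbers for stronger inhibition of growth), compound 1 `CCc1nc(C(=O)OC)nn1-c1ccc(F)cc1` gives 11000 nM. Compound 2 `COC(=O)c1nc(C(C)C)n(-c2ccc(F)cc2)n1` reaches only the limit of the assay, > 100000 nM, and so stands at the weak end of the numbers shown. Within the data shown here, the one measured step that bears on the change ahead is an at least 9.0-fold higher number from compound 1 to compound 2 (0.95 log units; beyond the scatter), which also alters the chain on the same ring carbon. Compound 3 `CCCCc1nc(C(=O)OC)nn1-c1ccc(F)cc1` differs from compound 2 by butyl in place of isopropyl on an aromatic carbon. The chain becomes straight again, as in compound 1, so the expected step of an at least 3.3-fold lower number from compound 2 to compound 3 (0.52 log units; beyond the scatter) is toward stronger inhibition, though uncertain. Compound 3 is therefore expected to give 30000 nM, between 8000 nM and 120000 nM.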

Compound 3, concentration for 50% growth inhibition: > 100000 nM
Compound 3: no number, only a limit (the forecaster's own chance of this, stated with the estimate: 40%); middle value at least 3.3-fold (0.52 log units) away from the limit.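

In this assay, a straight butyl chain on this aromatic carbon gives an at least 9.0-fold higher number from compound 1 to compound 3 (0.95 log units; beyond the scatter), so the loss of growth inhibition is not tied to a branched chain alone. Of the three chains shown, only ethyl gives a number rather than a limit. The step between compound 2 and compound 3 cannot be read, because both compounds stop at the same limit: the limit of > 100000 nM in this assay, at which 2 of the 3 values shown sit.

From the compounds shown here alone, whether a methyl or a propyl group on this carbon would give stronger or weaker inhibition than ethyl stays open. So does the effect of a cyclopropyl ring or an amine there.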